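Three inactive amides and a cyclohexyl analogue awaiting measurement

The compounds below may be only part of what the source reports. "The series", "measured", "known", "first", "only" and "open" are said of these compounds alone.

Compounds measured in a functional assay on HeLa cells (Homo sapiens) for cytotoxicity, read by MTT assay, with a stated time of 24 h; a higher number here means a weaker inhibitor, a lower number a stronger inhibitor:
compound 1 `C=CC1=C(C(=O)NCCC)C(c2ccc(Cl)c(Cl)c2)OC1` — reported only as a limit, > 100000 nM
compound 2 `C=CC1=C(C(=O)NCc2ccccc2F)C(c2ccc(F)cc2)OC1` — reported only as a limit, > 100000 nM
compound 3 `C=CC1=C(C(=O)Nc2ccc(OCC)cc2)C(c2ccc(OC)cc2)OC1` — reported only as a limit, > 100000 nM

Compound 2 stands among three compounds for which this assay returns no number at all. Among the measured compounds shown here, the evidence is summed up by the limit of > 100000 nM in this assay, at which 3 of the 3 values shown sit, so nothing distinguishes compound 2 from compound 1 or compound 3 on these figures, and no step between measured compounds can be computed, because each value is a limit rather than a number.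

Compound 4 `C=CC1=C(C(=O)NC2CCCCC2)C(c2ccc(F)cc2)OC1` differs from compound 2 by cyclohexyl in place of 2-fluorobenzyl on an amide-type nitrogen. Since compound 2 has only a limit, the direction of this change cannot be read from any measured step, and the expected step from compound 2 to compound 4 is a step that the limit leaves unreadable from compound 2 to compound 4, meaning no movement beyond the scatter is expected. The most likely outcome is that compound 4 again falls outside the measurable range of this assay. Compound 4 is therefore estimated at 150000 nM, with an expected range from 50000 nM to 500000 nM, and most probably reported as a limit only.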

Compound 4, half-maximal inhibitory concentration: > 100000 nM
Compound 4: a limit, no number; the forecaster's own chance of this, stated with the estimate: 85%; the middle value does not contradict the limit.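

In this assay compound 4 gives > 100000 nM as a limit and not a number. Among the compounds shown here, compound 2 is also reported only as a limit, so no step between compound 2 and compound 4 can be read. The compounds shown leave open whether any change to the amide substituent or the shared core gives a measurable value in this assay at all.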